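The compounds below may be only part of what the source reports. "The series", "measured", "known", "first", "only" and "open" are said of these compounds alone.

Measured in a functional assay on BT-474 cells (Homo sapiens) for inhibition, read by CellTiter-Glo, with a stated time of 72 h; on this read-out higher numbers stand for weaker inhibition and lower numbers for stronger inhibition:
- compound 1 `Cc1cc(Nc2ncnc3cc(O)c(NC(=O)/C=C/[C@H]4CCCN4C)cc23)ccc1Oc1cnc2ccnn2c1` gives 3.11 nM
- compound 2 `Cc1cc(Nc2ncnc3cc(O)c(NC(=O)/C=C/[C@H]4CCCN4C)cc23)ccc1Oc1cnn2cnnc2c1` gives 20.8 nM

Of these two, compound 2 has the higher number, which makes it the weaker inhibitor. Compound 3 `Cc1cc(Nc2ncnc3cc(O)c(NC(=O)/C=C/[C@H]4CCCN4C)cc23)ccc1Oc1ccc2nccn2c1` differs from compound 2 in one place, on an oxygen on an aromatic ring, where a group of 9 heavy atoms (7 carbon, 2 nitrogen; one five-membered aromatic ring with 2 hetero atoms, one six-membered aromatic ring with 1 hetero atom) in place of a group of 9 heavy atoms (5 carbon, 4 nitrogen; one five-membered aromatic ring with 3 hetero atoms, one six-membered aromatic ring with 2 hetero atoms), on an oxygen on an aromatic ring is the swap. Within the data shown here, only one measured step bears on this, at that same place: a 6.7-fold higher number from compound 1 to compound 2 (0.83 log units; beyond the scatter) came with a group holding more nitrogen. Among the measured compounds shown here, the new group in compound 3 holds less nitrogen than either, but it is a different group from the one in compound 1, and a single step is a thin guide. A lower number of similar size is therefore expected, estimated as a 3.5-fold lower number from compound 2 to compound 3 (0.54 log units; beyond the scatter) in this assay as a rough figure. For compound 3 the estimate is 6 nM with an expected range from 1.5 nM to 20 nM as its limits.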

Compound 3, half-maximal inhibitory concentration: 5.22 nM
Beside the measured number, compound 3's estimate is 1.1-fold (0.06 log units) above it; the measured number falls inside the stated range.
By their numbers in this assay, from the lowest: compounds 1 and 3 (each within the scatter of the next); then compound 2.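

In this assay, among these compounds, the swap at this oxygen gives a 4.0-fold lower number from compound 2 to compound 3 (0.60 log units; beyond the scatter) and so shows that the number here can move in both directions, not only upward as in the one earlier step. The other new comparison gives a 1.7-fold higher number from compound 1 to compound 3 (0.22 log units; within the scatter) and leaves those two compounds indistinguishable, so compound 2, with its group of 5 carbon and 4 nitrogen, is the weakest of the three, while two different groups with less nitrogen perform alike. Nothing measured here explains this difference.

These compounds cannot separate the number of ring nitrogens from where they sit or from the shape of the two-ring group. A single pyridine ring or a plain phenyl ring at this oxygen would test whether both rings of the group are needed at all.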